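The source may report more compounds than this note shows. Statements on the series, on what has been measured and on what is new or still open speak of the compounds shown alone.

Compound 2, `CN(C)C(=S)SCC(CSC(=S)N(C)C)C(=O)c1ccc(F)cc1`, gives 1210 nM in a functional assay on NCI-H460 cells (Homo sapiens) for inhibition, read by MTT assay, with a stated time of 72 h; a higher number here means a weaker inhibitor, a lower number a stronger inhibitor. Compound 1, `CN(C)C(=S)SCC(CSC(=S)N(C)C)C(=O)c1ccccc1`, gives 1930 nM. Compound 3, `CN(C)C(=S)SCC(CSC(=S)N(C)C)C(=O)c1nccs1`, gives 840 nM.

Among these three numbers compound 2 stands second highest, with compound 3 nearest and compound 1 furthest, and both of those gaps lie within the scatter. Compound 4, `CN(C)C(=S)SCC(CSC(=S)N(C)C)C(=O)c1ccc[nH]1`, is not yet measured. It differs from compound 2 as follows: 1H-pyrrol-2-yl in place of 4-fluorophenyl on a carbonyl carbon.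

Among the compounds with values here, two measured steps bear on this kind of change, in which the ring on the carbonyl carbon is swapped for a five-membered aromatic ring with hetero atoms: a 2.3-fold lower number from compound 1 to compound 3 (0.36 log units; beyond the scatter) and a 1.4-fold lower number from compound 2 to compound 3 (0.16 log units; within the scatter). The first is modest, the second within the scatter. A similar or smaller shift is therefore expected for compound 4, perhaps a lower number, though not clearly beyond the scatter, because a 1.4-fold lower number from compound 2 to compound 3 (0.16 log units; within the scatter) shows only a small change. Compound 4 is expected to give about 900 nM, between 400 nM and 2000 nM, which would be a step of a 1.3-fold lower number from compound 2 to compound 4 (0.13 log units; within the scatter).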

Compound 4, half-maximal inhibitory concentration: 97300 nM
Beside the measured number, compound 4's estimate is 110-fold (2.03 log units) below it, and the stated range ends below it.
By their numbers in this assay, from the lowest: compounds 3, 2 and 1 (each within the scatter of the next, the first and the last beyond it); then compound 4.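

Within the data shown here, this position on the carbonyl carbon proves far less forgiving than the earlier compounds suggested: in this assay the swaps among phenyl, 4-fluorophenyl and 1,3-thiazol-2-yl shifted the number little, yet 1H-pyrrol-2-yl brings an 80-fold higher number from compound 2 to compound 4 (1.91 log units; beyond the scatter) and a 120-fold higher number from compound 3 to compound 4 (2.06 log units; beyond the scatter) and a 50-fold higher number from compound 1 to compound 4 (1.70 log units; beyond the scatter). Compound 3 and compound 4 both carry a five-membered aromatic ring with a hetero atom, so that ring type alone does not guarantee a low number. Of the four groups, only 1H-pyrrol-2-yl counts a hydrogen-bond donor, but nothing measured here explains the loss.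

From the compounds shown here alone, it stays open whether the hydrogen on the ring nitrogen goes with this loss. A 1-methyl-1H-pyrrol-2-yl or furan-2-yl group on the same carbonyl carbon would test that.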